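Trading a Carbamoyl Group for Isopropyl on the Side Chain

The source may report more compounds than this note shows. Statements on the series, on what has been measured and on what is new or still open speak of the compounds shown alone.

Of the compounds shown here, two have been tested in a functional assay on the whole organism (Tail, strain ICR) with Mus musculus as the target, in the tail flick test, with a stated time of 90 min, at a dose of 25 umol/kg by the oral route; on this read-out higher numbers stand for a stronger effect at the one dose given and lower numbers for a weaker effect. Compound 1 `O=C(CN(c1ncnc2c1ncn2C1CCCCO1)C1CC1)N[C@@H](CCC(=O)OCc1ccccc1)C(=O)OCc1ccccc1` gives 25.2%, and compound 2 `NC(=O)C[C@H](NC(=O)CN(c1ncnc2c1ncn2C1CCCCO1)C1CC1)C(=O)OCc1ccccc1` gives 35%. The change between them, a number 9.8 percentage points higher from compound 1 to compound 2 (within the scatter), is a shift too small to count as a real difference. Compound 2 thus holds the higher of the two numbers seen, yet the gap to compound 1 lies inside the scatter, so no order can be read from it.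

Compound 3 `CC(C)C[C@H](NC(=O)CN(c1ncnc2c1ncn2C1CCCCO1)C1CC1)C(=O)OCc1ccccc1` is not yet measured. It differs from compound 2 in one spot: isopropyl in place of carbamoyl on a saturated chain carbon, two bonds along the chain from an amide-type nitrogen and a carbonyl carbon. For the measured compounds named here, the only measured step, from compound 1 to compound 2, changed the same position but with different groups, and that step stayed within the scatter. Going by the values given here, no step with isopropyl entering has been measured, so nothing in the data points to a larger movement in this assay in either direction. The expectation is therefore a change no bigger than the scatter, a number 5 percentage points lower from compound 2 to compound 3 (within the scatter). For compound 3 the estimated result in this assay is 30%, with a range from 15% to 45%.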

Compound 3, a percentage reported as activity, at one dose (the size of the read-out at that dose, not a potency): 28.2%
Estimate against measurement, compound 3: 1.8 percentage points above, and the stated range covers the measured number.
By their numbers in this assay, from the lowest: compounds 1, 3 and 2 (each within the scatter of the next).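

In this assay, isopropyl carries no hydrogen-bond donors or acceptors where carbamoyl has one of each, yet this exchange between groups of equal heavy-atom count gives a number 6.8 percentage points lower from compound 2 to compound 3 (within the scatter), so removing the donor and the acceptor together leaves no readable mark at this dose. Set against the (benzyloxycarbonyl)methyl group, isopropyl gives a number 3 percentage points higher from compound 1 to compound 3 (within the scatter), which means that all three groups on this saturated chain carbon now read alike in this assay, whether the group is a small hydrocarbon, a small amide or a benzyl ester. No measurement here explains this sameness.

Going by these compounds, whether a free carboxylic acid, an amine or a longer hydrocarbon chain on the same carbon would stay within this narrow band remains open, and so does whether any group at this position can move the read-out clearly at all. On these data alone, a result at a single dose and a single time also cannot show whether these compounds would separate at a different dose, so their relative potency remains unknown.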